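The source may hold more compounds than are shown below. What is called first, only, known or untested is meant among the compounds shown, and "the series" means these compounds.

Measured compounds in a functional assay on A549 cells (Homo sapiens) for antiproliferative activity, read by sulforhodamine B assay, with a stated time of 72 h; a higher number here means a weaker inhibitor, a lower number a stronger inhibitor:
compound 1 `CCCCS(=O)(=O)Nc1cc(-c2ccc3ncnc(Nc4ccc(OCCO)nc4)c3c2)cnc1OC` — 13300 nM
compound 2 `COc1ncc(-c2ccc3ncnc(Nc4cnn(CCCO)c4)c3c2)cc1NS(=O)(=O)c1ccc(F)cc1F` — 4830 nM
compound 3 `COc1ncc(-c2ccc3ncnc(Nc4cnn(CCCO)c4)c3c2)cc1NS(C)(=O)=O` — 3600 nM

Compound 3 gives the lowest number of the three in this assay. Its nearest neighbour is compound 2, and the step of a 1.3-fold lower number from compound 2 to compound 3 (0.13 log units; within the scatter) is within the scatter, so the two cannot be ordered. Compound 1 lies furthest off; the gap between compound 1 and compound 3 is beyond the scatter, but compound 1 differs from compound 3 in more than one place, so only the two values themselves are known.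

Compound 4 `COC(=O)CCn1cc(Nc2ncnc3ccc(-c4cnc(OC)c(NS(C)(=O)=O)c4)cc23)cn1` is not yet measured in this assay. It differs from compound 3 in one place: methoxycarbonyl in place of hydroxymethyl on a saturated chain carbon, two bonds along the chain from an aromatic nitrogen. Among the compounds with values here, no measured step touches this part of the molecule; the single-point step from compound 2 to compound 3 concerns the group on the sulfonyl sulfur and says nothing about a saturated chain carbon two bonds along the chain from an aromatic nitrogen. With no bearing data, no step beyond the scatter is assumed in either direction. Compound 4 is therefore expected to give 3600 nM (range 1800 nM to 7200 nM). The estimated step is no change at the digits printed from compound 3 to compound 4 (within the scatter).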

Compound 4, half-maximal inhibitory concentration: 2990 nM
For compound 4 the middle estimate is 1.2-fold (0.08 log units) above the measured one, within the range that was stated.
By their numbers in this assay, from the lowest: compounds 4, 3 and 2 (each within the scatter of the next); then compound 1.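

In this assay, this saturated chain carbon, two bonds along the chain from an aromatic nitrogen, now has a measured step (a 1.2-fold lower number from compound 3 to compound 4 (0.08 log units; within the scatter)), so compound 3 and compound 4 cannot be ordered. The change replaces hydroxymethyl, with its hydrogen-bond donor, by methoxycarbonyl, which has no donor and more heavy atoms, and the reading stays within the scatter; a donor on this carbon is therefore not needed to hold a number of this size in this series. No measurement at hand accounts for this result.

On these data alone, it remains open whether a carboxylic acid or an amine in place of methoxycarbonyl on this carbon, or a longer chain bearing the ester, would give a step beyond the scatter. As far as these compounds go, it is also open whether the same exchange behaves alike with 2,4-difluorophenyl on the sulfonyl sulfur, as in compound 2.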